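This account rests on a few compounds, and the source may have more. Where it says the series, first, only, none or still open, it means among the compounds named here.

The three measured compounds share a sulfonamide linkage but sit on two different cores. Compound 1 `COc1ccc(Cl)cc1S(=O)(=O)Nc1ccc2oc(-c3ccccc3)nc2c1` carries a 5-chloro-2-methoxyphenyl on the sulfonyl sulfur, and compound 2 `O=S(=O)(Nc1ccc2oc(-c3ccccc3)nc2c1)c1ccc(Cl)c(Cl)c1` differs from it by 3,4-dichlorophenyl in place of 5-chloro-2-methoxyphenyl on a sulfonyl sulfur. In an assay on isolated protein for inhibition of malate dehydrogenase, mitochondrial (Sus scrofa), with stated times of 45 min and 30 min (on this read-out higher numbers stand for weaker inhibition and lower numbers for stronger inhibition), compound 1 gives only a limit of the assay, > 63000 nM. Compound 2 likewise gives only a limit in this assay, > 63000 nM. The step that the two limits leave unreadable from compound 1 to compound 2 therefore cannot be read, because both values sit at the limit of > 63000 nM in this assay, at which 3 of the 3 values shown sit.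

Compound 3 `COc1ccc(Cl)cc1S(=O)(=O)Nc1ccc(-c2nc3ccccc3o2)cc1` is built from the same atoms as compound 1, joined differently; the difference between the two cores is not broken down here. In this assay compound 3 again gives only a limit, > 63000 nM.

Compound 4 `O=S(=O)(Nc1ccc(-c2nc3ccccc3o2)cc1)c1ccc(Cl)c(Cl)c1` has not yet been measured. It differs from compound 3 by 3,4-dichlorophenyl in place of 5-chloro-2-methoxyphenyl on a sulfonyl sulfur, which is the same change as that from compound 1 to compound 2, with the place described in the same words in both cases. Since the earlier step left no readable size and all three known values sit at the limit of > 63000 nM in this assay, at which 3 of the 3 values shown sit, the step that the limit leaves unreadable from compound 3 to compound 4 is expected to be small or unreadable. Compound 4 is estimated at 100000 nM, within a range from 63000 nM to 300000 nM, and it is expected that the assay will most likely report only a limit for compound 4 as well.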

Compound 4, half-maximal inhibitory concentration: > 63000 nM
Compound 4: only a limit was reported; the forecaster's own chance of this, stated with the estimate: 85%; the middle value does not contradict the limit.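

Compound 4 again gives only a limit in this assay, > 63000 nM. No size can be read for the change from compound 3 to compound 4, and the same holds for the change from compound 1 to compound 2: the limit of > 63000 nM in this assay, at which 4 of the 4 values shown sit. The compounds shown leave open whether either sulfonyl substituent or either core makes any difference to inhibition, since none of them yields a number.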